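This account rests on a few compounds, and the source may have more. Where it says the series, first, only, none or still open, it means among the compounds named here.

Three measured compounds frame the question. Compound 1 `c1ccc2c(c1)CN[C@@H](CN(CC[C@@H]1CCCNC1)[C@H]1CCCc3cccnc31)C2` gives 161 nM in a functional assay on CCRF-CEM cells for antagonist activity at C-X-C chemokine receptor type 4 (Homo sapiens), read by calcium flux, with stated times of 25 min and 90 s (a higher number here means a weaker inhibitor, a lower number a stronger inhibitor), the lowest number of the three. Compound 3 `c1cnc2c(c1)CN[C@@H](CN(CCCN1CCNCC1)[C@H]1CCCc3cccnc31)C2` gives 171 nM, which sits within the scatter of compound 1, while compound 2 `c1cnc2c(c1)CN[C@H](CN(CCCN1CCNCC1)[C@H]1CCCc3cccnc31)C2` gives 2640 nM. Among the compounds with values here, the one measured step is a 15-fold lower number from compound 2 to compound 3 (1.19 log units; beyond the scatter), and it rests on (the fact that compounds 2 and 3 differ only in the configuration as drawn), so a single inversion at a saturated ring carbon can move this assay by a large amount.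

Compound 4 `c1ccc2c(c1)CN[C@@H](CN(CC[C@H]1CCCNC1)[C@H]1CCCc3cccnc31)C2` is related to compound 1 in the same manner: the two compounds have the same atoms and bonds and differ only in configuration as drawn: 1 of 3 stereo elements differ; a stereocentre at a saturated ring carbon is drawn S in compound 1 and R in compound 4. The stereocentre inverted here is of the same kind as in the measured step but is not the same stereo element, so that step gives the scale such inversions can reach rather than a direction for this one. Compound 1 already holds the lowest number shown, and an inversion is more often costly than free, so compound 4 is expected to give a somewhat higher number, a 2.2-fold higher number from compound 1 to compound 4 (0.34 log units; beyond the scatter). Compound 4 is therefore estimated at 350 nM, with a range from 120 nM to 1200 nM.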

Compound 4, half-maximal inhibitory concentration: 16 nM
Compound 4: middle estimate off by 22-fold (1.34 log units), on the high side, and the stated range ends above it.
By their numbers in this assay, from the lowest: compound 4; then compounds 1 and 3 (each within the scatter of the next); then compound 2.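

With a 10-fold lower number from compound 1 to compound 4 (1.00 log units; beyond the scatter), this saturated ring carbon proves to be a second stereocentre at which a single inversion moves this assay beyond the scatter, and it shows that the direction here is downward from S to R as drawn, which the earlier step at a different stereo element could not tell. That step, a 15-fold lower number from compound 2 to compound 3 (1.19 log units; beyond the scatter), also runs from S to R as drawn, but the two pairs involve different stereo elements, so they make two separate observations and not one rule. The change from compound 1 to compound 4 is confined to this one centre: the fact that compounds 1 and 4 differ only in the configuration as drawn

The compounds shown leave open whether the lower number at this R carbon would persist with a longer chain or a carboxylic acid in the same part of compound 4. They also leave open what inverting the remaining stereocentres of compound 4 would do.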